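This account rests on a few compounds, and the source may have more. Where it says the series, first, only, none or still open, it means among the compounds named here.

Measured compounds:
compound 1 `COc1nc(C)c(Nc2nc(Cl)cn([C@H](COC(=O)c3cccnc3)C3CC3)c2=O)cc1C` — 5.2 nM
compound 2 `COc1nc(C)c(Nc2nc(Cl)cn([C@H](COC(=O)Nc3ccccc3)C3CC3)c2=O)cc1C` — 1.5 nM
compound 3 `COc1ccc(NC(=O)OC[C@H](C2CC2)n2cc(Cl)nc(Nc3cc(C)c(OC)nc3C)c2=O)c(C)n1` — 9.2 nM

In an assay on frontal cortex for displacement of a labelled ligand from corticotropin-releasing factor receptor 1 (Rattus norvegicus), with a stated time of 2 h (a higher number here means a weaker inhibitor, a lower number a stronger inhibitor), compound 2 stands lowest of the three numbers, with compound 1 nearest and compound 3 furthest. Both measured steps away from it lie beyond the scatter: a 3.5-fold lower number from compound 1 to compound 2 (0.54 log units; beyond the scatter) and a 6.1-fold higher number from compound 2 to compound 3 (0.79 log units; beyond the scatter). The third step, a 1.8-fold higher number from compound 1 to compound 3 (0.25 log units; within the scatter), stays within the scatter. All three steps exchange the group attached to the carbonyl carbon or to the amide-type nitrogen; none of them alters the anilino-bearing side that compounds 1, 2 and 3 share in the portion attached to the pyrimidinone-type nitrogen.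

Compound 4 `Cc1cc(Nc2nc(Cl)cn([C@H](COC(=O)Nc3ccccc3)C3CC3)c2=O)c(C)nc1OC(F)F` keeps the whole of compound 2 except for one change: difluoromethyl in place of methyl on an oxygen on an aromatic ring. Going by the values given here, no measured step touches this oxygen-bound methyl, so nothing here bears directly on the change; the only guidance is that the measured variations all sit elsewhere and that the methoxy-bearing ring is constant across the set. In the absence of a relevant precedent the expected step in this assay is none beyond the scatter, with the estimate placed close to compound 2 and widened to allow for the unknown: a 1.3-fold higher number from compound 2 to compound 4 (0.12 log units; within the scatter) is the expected step. For compound 4 the estimated value in this assay is 2 nM, within a range of 0.7 nM to 6 nM.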

Compound 4, half-maximal inhibitory concentration: 0.74 nM
Beside the measured number, compound 4's estimate is 2.7-fold (0.43 log units) above it; measured number inside the range.
By their numbers in this assay, from the lowest: compound 4; then compound 2; then compounds 1 and 3 (each within the scatter of the next).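

In this assay the oxygen-bound methyl, constant across compounds 1, 2 and 3, proves to be a place where the number can still move: methoxy to difluoromethoxy gives a 2.0-fold lower number from compound 2 to compound 4 (0.31 log units; beyond the scatter). Going by these compounds alone, this is the first measured change on this side of the molecule, as all earlier steps exchanged the group on the carbonyl carbon or the amide-type nitrogen, and it shows that the two added fluorine atoms are accepted here with a modest fall in the number rather than a loss. The compounds shown offer no accompanying measurement that could account for this step.

Difluoromethyl on this oxygen appears only with the anilino group on the carbonyl carbon, so it remains open whether the step carries over to the pyridin-3-yl of compound 1 or to the (6-methoxy-2-methylpyridin-3-yl)amino of compound 3. Also open, going by these compounds, is how far this oxygen substituent can be taken, for instance to trifluoromethyl or ethyl, and whether the number keeps falling or turns back up with those groups.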